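A few compounds are considered here, and "the series" means these few. Any claim that something is new, unique, unknown or untested is made for them only; others in the source may bear on it.

Three compounds share one core and differ only in the group on a six-membered aromatic ring of carbon only. In an assay on isolated protein for inhibition of ubiquitin carboxyl-terminal hydrolase 7 (Homo sapiens), with stated times of 30 min and 2 h (on this read-out lower numbers stand for stronger inhibition and higher numbers for weaker inhibition), compound 1 `Cn1nc2c(=O)n(CC3(O)CCN(Cc4ccc(-c5ccco5)cc4Cl)CC3)cnc2c1-c1ccc(CNCCO)cc1` gives 8.2 nM, compound 2 `Cn1nc2c(=O)n(CC3(O)CCN(Cc4ccc(-c5ccco5)cc4Cl)CC3)cnc2c1-c1ccc(C(N)=O)cc1` gives 80.8 nM, and compound 3 `Cn1nc2c(=O)n(CC3(O)CCN(Cc4ccc(-c5ccco5)cc4Cl)CC3)cnc2c1-c1ccc(CNC=O)cc1` gives 20.9 nM, which puts compound 3 second highest of the three, with compound 1 nearest and compound 2 furthest. Compound 4 `Cn1nc2c(=O)n(CC3(O)CCN(Cc4ccc(-c5ccco5)cc4Cl)CC3)cnc2c1-c1ccc(Cl)cc1` carries chloro in place of (formylamino)methyl on an aromatic carbon. Two measured steps change the same position: a 2.5-fold higher number from compound 1 to compound 3 (0.41 log units; beyond the scatter) and a 3.9-fold lower number from compound 2 to compound 3 (0.59 log units; beyond the scatter), both modest and both beyond the scatter. Removing the group altogether is expected to raise the number again, by about a 4.8-fold higher number from compound 3 to compound 4 (0.68 log units; beyond the scatter). Compound 4 is therefore estimated at 100 nM, with a likely range from 30 nM to 400 nM.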

Compound 4, half-maximal inhibitory concentration: 143 nM
Estimate against measurement, compound 4: 1.4-fold (0.16 log units) below; the measured number falls inside the stated range.
By their numbers in this assay, from the lowest: compound 1; then compound 3; then compounds 2 and 4 (each within the scatter of the next).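

With chloro on this aromatic carbon the number rises well clear of the two groups that hold a nitrogen on a methyl carbon (a 6.8-fold higher number from compound 3 to compound 4 (0.84 log units; beyond the scatter); a 17-fold higher number from compound 1 to compound 4 (1.24 log units; beyond the scatter)), and the second of these is the largest step among these compounds. Against carbamoyl the change stays within the scatter (a 1.8-fold higher number from compound 2 to compound 4 (0.25 log units; within the scatter)), so carbamoyl shows no measurable edge over chloro here.

On these data alone, whether a plain aminomethyl group or a carboxylic acid would match compound 1 remains open. No measurement shown here accounts for these differences.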